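Chalcone-linked series: swapping the aryl ketone for chlorophenyl

The compounds below may be only part of what the source reports. "The series", "measured", "known", "first", "only" and "open" are said of these compounds alone.

Two members of this series have been run in a functional assay on MDA-MB-231 cells (Homo sapiens) for antiproliferative activity, read by MTT assay, with a stated time of 24 h; a higher number here means a weaker inhibitor, a lower number a stronger inhibitor. Compound 1 `COc1ccc(-c2cc(/C=C/C(=O)c3ccc(Cl)cc3)nc3cc(-c4ccccc4)nn23)cc1OC` carries a 4-chlorophenyl on its carbonyl carbon and a 3,4-dimethoxyphenyl on the shared core; in this assay compound 1 gives 17100 nM. Compound 2 `COc1ccc(C(=O)/C=C/c2cc(-c3cc(OC)c(OC)c(OC)c3)n3nc(-c4ccccc4)cc3n2)cc1OC` carries the 3,4-dimethoxyphenyl on the carbonyl carbon instead and a 3,4,5-trimethoxyphenyl on the core; in this assay compound 2 gives 18300 nM. The two numbers sit within the scatter of each other, so the data so far give no step beyond the noise.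

Compound 3 `COc1cc(-c2cc(/C=C/C(=O)c3ccc(Cl)cc3)nc3cc(-c4ccccc4)nn23)cc(OC)c1OC` differs from compound 2 in one place: 4-chlorophenyl in place of 3,4-dimethoxyphenyl on a carbonyl carbon. Within the data shown here, no measured pair shows this change directly. Compound 3 therefore ends up with the same (4-chlorophenyl)carbonyl as compound 1 while keeping the trimethoxyphenyl of compound 2, and both measured numbers sit at much the same level. Compound 3 is expected at 17000 nM, with a range of 8000 nM to 36000 nM, because compound 1 gives 17100 nM with the same 4-chlorophenyl on its carbonyl carbon. The step of a 1.1-fold lower number from compound 2 to compound 3 (0.03 log units; within the scatter) is expected to remain within the scatter, with no clear direction.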

Compound 3, half-maximal inhibitory concentration: 32500 nM
Compound 3: middle estimate off by 1.9-fold (0.28 log units), on the low side; measured number inside the range.
By their numbers in this assay, from the lowest: compounds 1, 2 and 3 (each within the scatter of the next).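

In this assay, the carbonyl carbon whose other neighbour is the double-bonded chain carbon now has a direct reading: 4-chlorophenyl in place of 3,4-dimethoxyphenyl gives a step that stays inside the noise (a 1.8-fold higher number from compound 2 to compound 3 (0.25 log units; within the scatter)). The added methoxy, in place of hydrogen on an aromatic carbon, likewise gives a step that does not clear the noise (a 1.9-fold higher number from compound 1 to compound 3 (0.28 log units; within the scatter)), so neither single change separates these compounds, even though the first swaps a ring with two methoxy groups for one with a chlorine and no hydrogen-bond acceptors. No measurement to hand bears on why these numbers fall as they do.

Going by these compounds, whether any group on this carbonyl carbon can shift the read-out beyond the scatter remains open; a pyridine ring, or a phenyl carrying an amine or a carboxylic acid, would test this more sharply than another substituted phenyl with neutral groups. Also open, on these data alone, is whether a core aryl with no methoxy groups, such as plain phenyl, would stay at the same level as the methoxy-bearing rings seen here.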